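The source may hold more compounds than are shown below. What is called first, only, known or untested is meant among the compounds shown, and "the series" means these compounds.

Measured so far:
Compound 1, `Cc1cn(C2CC(N=[N+]=[N-])C(COC(=O)NCCCN)O2)c(=O)[nH]c1=O`: in an ADME assay on the whole organism (serum) with Homo sapiens as the target (on this read-out lower numbers stand for a shorter-lived compound and higher numbers for a longer-lived compound), compound 1 gives > 48 h, which is a limit of the assay rather than a number (the limit of > 48 h in this assay, at which 1 of the 2 values shown sits).
Compound 2, `Cc1cn(C2CC(N=[N+]=[N-])C(COC(=O)OCCO)O2)c(=O)[nH]c1=O`: in this assay compound 2 gives < 0.0167 h, again a limit of the assay rather than a number (the limit of < 0.0167 h in this assay, at which 1 of the 2 values shown sits).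

Compound 2 therefore stands at the short end of the two values shown, while the other value sits at the long end. Within the data shown here, the one measured step, an at least 2800-fold lower number from compound 1 to compound 2 (3.45 log units; beyond the scatter), is large and beyond the scatter; it swaps the whole group on the carbonyl carbon.

Compound 3, `Cc1cn(C2CC(N=[N+]=[N-])C(COC(=O)OCCCC(=O)O)O2)c(=O)[nH]c1=O`, differs from compound 2 by carboxymethyl in place of hydroxy on a saturated chain carbon, two bonds along the chain from an oxygen next to a carbonyl group. The carbonyl group and the oxygen next to it are kept, and the change sits further out along the chain than the measured step did, so that step bears on it only loosely. With the carbonate kept, no step beyond the scatter is expected, an at least 1.7-fold higher number from compound 2 to compound 3 (0.25 log units; that floor lies within the scatter). Compound 3 is estimated at 0.03 h, within 0.003 h to 0.5 h, and the assay may well again report only a limit for compound 3.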

Compound 3, half-life: 13 h
Compound 3: middle estimate off by 430-fold (2.64 log units), on the low side; measured number above the stated range.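

Swapping hydroxy for carboxymethyl on a saturated chain carbon, two bonds along the chain from an oxygen next to a carbonyl group, gives an at least 770-fold higher number from compound 2 to compound 3 (2.89 log units; beyond the scatter) in this assay, so a change this far out on the chain can still move the half-life a long way, and keeping the carbonate does not fix the number. This step is only a floor, as compound 2 stands at a limit of the assay and not at a number: the limit of < 0.0167 h in this assay, at which 1 of the 3 values shown sits.

Compound 3 also shows that a carbonate can be long-lived here, although 3-carboxypropoxy in place of (3-aminopropyl)amino on the carbonyl carbon still gives an at least 3.6-fold lower number from compound 1 to compound 3 (0.56 log units; beyond the scatter), again only a floor, as compound 1 stands at a limit of the assay: the limit of > 48 h in this assay, at which 1 of the 3 values shown sits.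

The longer chain and the carboxy end enter together in compound 3, so the compounds shown cannot tell which of the two goes with the longer half-life. A 3-hydroxypropoxy group, with the longer chain alone, or a 2-carboxyethoxy group, with the carboxylic acid on a shorter chain, would pull the two apart.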